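The source may report more compounds than this note shows. Statements on the series, on what has been measured and on what is new or still open speak of the compounds shown alone.

Three compounds have so far been measured in a physicochemical assay for lipophilicity; a lower number here means a more polar compound, a higher number a more lipophilic compound:

Compound 1, `CCOC(=O)C1=C(C)NC(=O)NC1c1cn(C(=O)CNc2ccc([N+](=O)[O-])cc2)c2ccccc12`, gives 1.48.
Compound 2, `CCOC(=O)C1=C(C)NC(=O)NC1c1cn(C(=O)CNc2ccccc2N)c2ccccc12`, gives 0.74.
Compound 3, `CCOC(=O)C1=C(C)NC(=S)NC1c1cn(C(=O)CNc2ccc([N+](=O)[O-])cc2)c2ccccc12`, gives 2.88.

Compound 1 and compound 2 differ in a single place: 2-aminophenyl in place of 4-nitrophenyl on an amine nitrogen. That change produced a number 0.74 log units lower from compound 1 to compound 2 (beyond the scatter). Compound 3 sits highest of the three numbers; against compound 1 its value is higher by a margin that lies well beyond the scatter, and against compound 2 the gap is wider still. How the core of compound 3 differs from the core of compound 1 is not broken down here.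

Compound 4, `CCOC(=O)C1=C(C)NC(=S)NC1c1cn(C(=O)CNc2ccccc2N)c2ccccc12`, has not yet been measured in this assay. It differs from compound 3 in one place: 2-aminophenyl in place of 4-nitrophenyl on an amine nitrogen. This is the same change that separates compound 1 from compound 2, made at the same place, on an amine nitrogen whose other neighbours are a saturated chain carbon.

On that basis the step is expected to repeat. The estimate is that from compound 3 to compound 4 the change will amount to a number 0.74 log units lower from compound 3 to compound 4 (beyond the scatter), because the identical change from compound 1 to compound 2 gave a number 0.74 log units lower from compound 1 to compound 2 (beyond the scatter). Compound 4 is therefore expected to read 2.14 in this assay, most likely between 1.6 and 2.7. For the measured compounds named here, with only one earlier instance of the change to lean on, the width of that range reflects the usual scatter of the measurement rather than any further evidence.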

Compound 4, partition coefficient: 2.14
Estimate against measurement, compound 4: no gap at the digits printed; low and high end bracket the measured number.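

In this assay, putting 2-aminophenyl in place of 4-nitrophenyl on the amine nitrogen gave a number 0.74 log units lower from compound 3 to compound 4 (beyond the scatter), and the same change had earlier given a number 0.74 log units lower from compound 1 to compound 2 (beyond the scatter), so the step carried from the core of compound 1 to the core of compound 3 with no difference at the digits printed. This shows that, for these two pairs, the size of the step did not depend on which of the two cores carried it, even though the two pairs sit at different levels of the scale. For the compounds shown here, it rests on only two pairs and one change at one place, so it does not show that the step would hold on any further core, and nothing available bears on why it repeated.

The compounds shown leave open how much of the step belongs to the loss of the nitro group and how much to the arrival of the amine, a question that a plain phenyl or a 4-aminophenyl on the same amine nitrogen could settle. They also leave open whether the step would survive on a core with a carboxylic acid in place of the ethyl ester, or with a longer chain in place of the saturated chain carbon on that nitrogen.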